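The source may report more compounds than this note shows. Statements on the series, on what has been measured and on what is new or still open speak of the compounds shown alone.

In an ADME assay on L929 cells (Mus musculus) for cytotoxicity (on this read-out lower numbers stand for stronger inhibition and higher numbers for weaker inhibition), compound 3 `O=[N+]([O-])c1cn2c(n1)[S@@+]([O-])C[C@H](OCc1ccc(OC(F)(F)F)cc1)C2` gives > 10 ug/mL, which is a limit of the assay and not a number. Compound 1 `O=[N+]([O-])c1cn2c(n1)[S@+]([O-])C[C@H](OCc1ccc(OC(F)(F)F)cc1)C2` gives > 10 ug/mL, also a limit. Compound 2 `O=[N+]([O-])c1cn2c(n1)[S@@+]([O-])C[C@@H](OCc1ccc(OC(F)(F)F)cc1)C2` gives > 10 ug/mL, again a limit. Compound 3 therefore has no exact position and shares its standing with the other two: the limit of > 10 ug/mL in this assay, at which 3 of the 3 values shown sit.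

The last stereoisomer, compound 4 `O=[N+]([O-])c1cn2c(n1)[S@+]([O-])C[C@@H](OCc1ccc(OC(F)(F)F)cc1)C2`, is related to compound 3 as follows: the two compounds have the same atoms and bonds and differ only in configuration as drawn: 2 of 2 stereo elements differ (all stereocentres are inverted: mirror images); a stereocentre at a sulfur is drawn S in compound 3 and R in compound 4; a stereocentre at a saturated ring carbon is drawn R in compound 3 and S in compound 4.

The closest measured parallel is a step that the two limits leave unreadable from compound 1 to compound 2, which also joins mirror images. The other two measured steps, a step that the two limits leave unreadable from compound 1 to compound 3 and a step that the two limits leave unreadable from compound 2 to compound 3, change only the configuration at one stereocentre. None of these steps has a readable size, so they offer no direction to carry over.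

Among the measured compounds shown here, with no measured step showing any separation, no change beyond the scatter is expected, and the estimated step that the limit leaves unreadable from compound 3 to compound 4 has no expected direction. For compound 4 the expected value is 15 ug/mL, with an estimated range from 10 ug/mL to 50 ug/mL, and the assay will most likely report only a limit again.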

Compound 4, half-maximal inhibitory concentration: > 10 ug/mL
Compound 4 was reported as a limit; the forecaster's own chance of this, stated with the estimate: 85%; the middle value does not contradict the limit.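

Among the compounds shown here, compound 4 gives only a limit, as do compound 1, compound 2 and compound 3, so no step between compound 4 and any of these three can be read. Whether these four stereoisomers differ at all in this assay stays open, with every value at the same limit: the limit of > 10 ug/mL in this assay, at which 4 of the 4 values shown sit.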